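Trifluoromethoxy in place of fluoro: a limit expected again

A few compounds are considered here, and "the series" means these few. Any claim that something is new, unique, unknown or untested is made for them only; others in the source may bear on it.

- compound 1 `OC[C@H]1O[C@@H](n2cnc3c(NCc4ccccc4F)ncnc32)[C@H](O)[C@@H]1O` gives > 166000 nM as a limit
- compound 2 `COc1cccc(CNc2ncnc3c2ncn3[C@@H]2O[C@H](CO)[C@@H](O)[C@H]2O)c1OC` has "not determined" (no result reported) as its entry
- compound 3 `OC[C@H]1O[C@@H](n2cnc3c(NCc4ccc(F)c(F)c4F)ncnc32)[C@H](O)[C@@H]1O` gives > 166000 nM as a limit

In a functional assay on B16 cells (Mus musculus) for antiproliferative activity, with a stated time of 72 h (a lower number here means a stronger inhibitor, a higher number a weaker inhibitor), compound 1 gives > 166000 nM as a limit, not a number. Compound 4 `OC[C@H]1O[C@@H](n2cnc3c(NCc4ccccc4OC(F)(F)F)ncnc32)[C@H](O)[C@@H]1O` carries trifluoromethoxy in place of fluoro on an aromatic carbon, ortho to a large group (trifluoromethoxy in place of fluoro on an aromatic carbon). Going by the values given here, the one measured step bearing on this is a step that the two limits leave unreadable from compound 1 to compound 3 and it offers no size to carry over. What remains is the limit of > 166000 nM in this assay, at which 2 of the 3 values shown sit, and from this no step beyond the scatter is expected in this assay in either direction. The expected step is an at least 1.1-fold lower number from compound 1 to compound 4 (0.04 log units; that floor lies within the scatter) and another limit is the likeliest report. For compound 4 the estimated value is 150000 nM (expected range 50000 nM to 250000 nM).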

Compound 4, half-maximal inhibitory concentration: > 166000 nM
Compound 4: a limit, no number; the forecaster's own chance of this, stated with the estimate: 75%; at least 1.1-fold (0.04 log units) between middle value and limit.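

Going by these compounds alone, compound 1 and compound 4 both end in limits in this assay, so no step between them can be read. The compounds shown leave open whether any change on this aromatic ring would give a readable number, as the values stop at: the limit of > 166000 nM in this assay, at which 3 of the 4 values shown sit.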